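The source may hold more compounds than are shown below. What is called first, only, known or untested is meant among the compounds shown, and "the series" means these compounds.

Measured so far in a functional assay on SN12C cells (Homo sapiens) for inhibition, read by sulforhodamine B assay, with a stated time of 48 h; a higher number here means a weaker inhibitor of growth, a lower number a stronger inhibitor of growth:
- compound 1 `COc1ccc(-c2[nH]c3ccccc3c2/C=C(\C#N)S(=O)(=O)c2ccccc2)cc1`: 1500 nM
- compound 2 `COc1ccc(-c2[nH]c3ccc(OC)cc3c2/C=C(\C#N)S(=O)(=O)c2ccccc2)cc1`: 2300 nM

Among the measured compounds shown here, compound 2 holds the higher of the two numbers in this assay, with compound 1 as its only neighbour; the step of a 1.5-fold higher number from compound 1 to compound 2 (0.19 log units; within the scatter) lies within the scatter, so the two compounds are not separated by these data. For the measured compounds named here, the one structural step measured so far is a methoxy put in place of hydrogen on an aromatic carbon of the shared core, and it moved the number very little.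

Compound 3 `COc1ccc2[nH]c(-c3ccccc3)c(/C=C(\C#N)S(=O)(=O)c3ccccc3)c2c1` differs from compound 2 by hydrogen in place of methoxy on an aromatic carbon. Going by the values given here, no measured step touches this place; the step from compound 1 to compound 2 concerns a methoxy on a different ring and bears on it only loosely, as a sign that a methoxy on this scaffold moved the read-out little. Among the compounds with values here, with that as the only guide, no step beyond the scatter is expected here, in either direction. Compound 3 is estimated at 2300 nM in this assay, with a range of 900 nM to 6000 nM, meaning an expected step of no change at the digits printed from compound 2 to compound 3 (within the scatter).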

Compound 3, concentration for 50% growth inhibition: 7800 nM
The estimate for compound 3 lay 3.4-fold (0.53 log units) below the measured number; the whole stated range lies below it.
By their numbers in this assay, from the lowest: compounds 1 and 2 (each within the scatter of the next); then compound 3.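

In this assay, among the compounds shown here, the change from 4-methoxyphenyl to phenyl gives a 3.4-fold higher number from compound 2 to compound 3 (0.53 log units; beyond the scatter) and is the first step to lie beyond the scatter, so the methoxy para to a large group counts for growth inhibition in this pair, with the weaker inhibitor being the compound without it. This sets the position apart from the other methoxy place, where a 1.5-fold higher number from compound 1 to compound 2 (0.19 log units; within the scatter) did not separate the two compounds, so on these two pairs the read-out depends on where the methoxy sits and not merely on its presence on the scaffold. No measurement at hand gives a reason for the step, which therefore stands as an observation from a single pair.

As far as these compounds go, whether the methoxy itself is special at this position remains open, since a hydroxy group, an amine, a fluorine atom or a longer alkoxy chain in the same place would show if other groups keep the lower number. From the compounds shown here alone, it is also open whether the step keeps its size when the second methoxy on the shared core is replaced by hydrogen.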